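A few compounds are considered here, and "the series" means these few. Any claim that something is new, unique, unknown or untested is made for them only; others in the source may bear on it.

Going by the values given here, in a functional assay on KYSE-450 cells (Homo sapiens) for inhibition, read by CCK-8 assay, with a stated time of 48 h (a higher number here means a weaker inhibitor, a lower number a stronger inhibitor), compound 1 `COc1ccc(CN(C(=O)CSC(=S)N2CCCc3cc(OC)ccc32)c2cc(OC)c(OC)c(OC)c2)cc1` gives 5530 nM, the only true number so far. Compound 2 `COc1ccc(CN(C(=O)CSC(=S)N2CCN(C(=O)OC(C)(C)C)CC2)c2ccc(Br)cc2)cc1` reads > 20000 nM, which is a limit of the assay and not a number. Compound 3 `COc1cc(N(Cc2ccc(C)cc2)C(=O)CSC(=S)N2CCN(C(=O)OC(C)(C)C)CC2)cc(OC)c1OC` reads > 20000 nM, again only a limit. The standing of compound 3 is thus (the limit of > 20000 nM in this assay, at which 2 of the 3 values shown sit), so no measured potency exists to step from.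

The next structure is compound 4 `COc1ccc(CN(C(=O)CSC(=S)N2CCN(C(=O)OC(C)(C)C)CC2)c2cc(OC)c(OC)c(OC)c2)cc1O`, and the change is 3-hydroxy-4-methoxyphenyl in place of 4-methylphenyl on a saturated chain carbon bound to an amide-type nitrogen. Here 3-hydroxy-4-methoxybenzyl takes the place of 4-methylbenzyl. Among the compounds with values here, no measured step shows what this change does, so its size remains a judgement. The expectation leans on compound 1, which at 5530 nM shows that the series can give a number within the range of this assay. The expected step is an at least 10-fold lower number from compound 3 to compound 4 (1.00 log units; beyond the scatter), in the direction of a stronger inhibitor, and it is poorly bounded since it starts from a limit. Compound 4 may also stay at the limit. For compound 4 the estimated value is 2000 nM, with an expected range of 100 nM to 20000 nM.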

Compound 4, half-maximal inhibitory concentration: 76 nM
For compound 4 the middle estimate is 26-fold (1.42 log units) above the measured one; measured number outside the range, below it.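

The benzyl group on the amide-type nitrogen is a place where the series responds strongly: 3-hydroxy-4-methoxyphenyl in place of 4-methylphenyl gives an at least 260-fold lower number from compound 3 to compound 4 (2.42 log units; beyond the scatter) in this assay. Everything else in compound 4 matches compound 3, so one change at this place is enough to take the series from a limit of the assay to a measured number. The true size of the step stays open-ended, since its starting point is only a limit: the limit of > 20000 nM in this assay, at which 2 of the 4 values shown sit.

The hydroxy and methoxy groups enter together in this change, and the compounds shown do not separate their contributions. Going by these compounds, how an amine or a carboxylic acid on the same ring would read in this assay also remains open.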